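The source may report more compounds than this note shows. Statements on the series, on what has been measured and on what is new or still open speak of the compounds shown alone.

Measured so far in a physicochemical assay for solubility, at pH 7.4; on this read-out lower numbers stand for lower solubility and higher numbers for higher solubility:
Compound 1 `CCCCCCCc1cnc(-c2ccc(CNC(=O)[C@H]3NCC[C@@H]3O)cc2)s1`: 4.2 ug/mL
Compound 2 `CCCCCCCc1cn(-c2ccc(CNC(=O)[C@H]3NCC[C@@H]3O)cc2)nn1`: 3.1 ug/mL
Compound 3 `CCCCCc1nc(-c2ccc(CNC(=O)[C@H]3NCC[C@@H]3O)cc2)no1`: > 50 ug/mL, which is a limit of this assay and not a number.

Compound 3 stands apart from the other two: its result is only (the limit of > 50 ug/mL in this assay, at which 1 of the 3 values shown sits), so its true solubility is not pinned down. Compound 1 and compound 2 give plain numbers in this assay, close to each other.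

Compound 4 `O=C(NCc1ccc(-c2noc(C3CCCCC3)n2)cc1)[C@H]1NCC[C@@H]1O` has not yet been measured. It differs from compound 3 in one place: cyclohexyl in place of pentyl on an aromatic carbon. For the measured compounds named here, no measured pair shows this change, so nothing here tells how large its effect is. No step beyond the usual scatter is expected from compound 3 to compound 4, estimated as an at least 1.1-fold lower number from compound 3 to compound 4 (0.04 log units; that floor lies within the scatter). For compound 4 the expected solubility is 45 ug/mL, with a range from 15 ug/mL to 120 ug/mL.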

Compound 4, solubility: > 50 ug/mL
Compound 4 gave a limit, no number; the forecaster's own chance of this, stated with the estimate: 45%; middle value at least 1.1-fold (0.04 log units) away from the limit.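

For the compounds shown here, no step from compound 3 to compound 4 can be read: in this assay each of the two gives a limit, not a number. As far as these compounds go, whether cyclohexyl in place of pentyl changes this read-out at all stays open.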